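Extending the Alkyl Chain of a Limit-Bound Indole Amide

This account rests on a few compounds, and the source may have more. Where it says the series, first, only, none or still open, it means among the compounds named here.

Measured compounds:
compound 1 `CCCCCCCCCCCCNC(=O)[C@@H](NC(=O)c1cc2ccccc2o1)[C@@H](C)O` — 21300 nM
compound 2 `CCCCCCCCCCCCNC(=O)[C@@H](NC(=O)c1cc2ccccc2n1C)[C@@H](C)O` — > 200000 nM
compound 3 `C/C=C/C=C/C(=O)N[C@H](C(=O)NCCCCCCCCCCCC)[C@@H](C)O` — 200000 nM

In a functional assay on SW-620 cells (Homo sapiens) for cytotoxicity, read by MTT assay, with a stated time of 48 h (on this read-out higher numbers stand for weaker inhibition and lower numbers for stronger inhibition), compound 1 gives 21300 nM. Compound 2 gives > 200000 nM, which is a limit of the assay and not a number (the limit of > 200000 nM in this assay, at which 1 of the 3 values shown sits). Compound 3 gives 200000 nM. Both changes away from compound 1 raised the number: an at least 9.3-fold higher number from compound 1 to compound 2 (0.97 log units; beyond the scatter) and a 9.4-fold higher number from compound 1 to compound 3 (0.97 log units; beyond the scatter). Compound 4 `CCCCCCCCCCCCCCCCCCNC(=O)[C@@H](NC(=O)c1cc2ccccc2n1C)[C@@H](C)O` differs from compound 2 by hexyl in place of hydrogen on a saturated chain carbon, ten or more bonds along the chain from an amide-type nitrogen. Among the compounds with values here, every measured step alters the group on the carbonyl carbon, not the chain, so no measured step bears on this change. Compound 2 already stands at the limit, and the expected step of a number no higher from compound 2 to compound 4 (the limit leaves the size open) rests on no measured evidence. Compound 4 is therefore expected to give 200000 nM, within 60000 nM to 200000 nM, most probably again only a limit.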

Compound 4, half-maximal inhibitory concentration: 124000 nM
For compound 4 the middle estimate is 1.6-fold (0.21 log units) above the measured one; low and high end bracket the measured number.
By their numbers in this assay, from the lowest: compound 1; then compounds 4 and 3 (each within the scatter of the next).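

In this assay, within the data shown here, this is the first change to the chain rather than to the group on the carbonyl carbon, and hexyl in place of hydrogen gives an at least 1.6-fold lower number from compound 2 to compound 4 (0.20 log units; that floor lies within the scatter). Compound 4 has a measured number, whereas compound 2 has only a limit: the limit of > 200000 nM in this assay, at which 1 of the 4 values shown sits. From the compounds shown here alone, the true size of the step therefore stays unknown, and the chain's effect cannot be told apart from the usual scatter.

Going by these compounds, whether a longer chain or an amine at this place would move the number remains open. So does whether hexyl acts the same way on compound 1.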